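Ring exchange on the thiocarbonyl carbon: thiomorpholine to piperidine

The compounds below may be only part of what the source reports. "The series", "measured", "known", "first", "only" and "open" are said of these compounds alone.

Measured in a functional assay on HeLa cells (Homo sapiens) for cytotoxicity, read by MTT assay, with a stated time of 72 h, tested at 1 uM; a lower number here means less inhibition of growth, a higher number more inhibition of growth at the concentration tested:
compound 1 `N/C(=N\NC(=S)N1CCOCC1)c1ccccn1`: 12.7%
compound 2 `N/C(=N\NC(=S)N1CCSCC1)c1ccccn1`: 25.1%

Compound 2 stands highest of the two numbers in this assay; the nearest number is that of compound 1, and a number 12.4 percentage points higher from compound 1 to compound 2 (beyond the scatter) is beyond the scatter. Compound 3 `N/C(=N\NC(=S)N1CCCCC1)c1ccccn1` is not yet measured. It differs from compound 2 in one place: piperidin-1-yl in place of thiomorpholin-4-yl on a thiocarbonyl carbon. Among the measured compounds shown here, only one measured step bears on this change, the exchange of one six-membered ring for another on the same thiocarbonyl carbon, namely a number 12.4 percentage points higher from compound 1 to compound 2 (beyond the scatter), which was modest in size. For the measured compounds named here, that step traded one ring heteroatom for another; the present change removes the second ring heteroatom altogether, and no measured pair shows what that does. The expectation is therefore set close to compound 2, with a wide range. For compound 3 the estimated step in this assay is a number 3.1 percentage points lower from compound 2 to compound 3 (within the scatter), which lies within the scatter. For compound 3 the expected value in this assay is 22%, with a range from 8% to 38%.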

Compound 3, percent growth inhibition at one concentration: 15.5%
For compound 3 the middle estimate is 6.5 percentage points above the measured one, within the range that was stated.
By their numbers in this assay, from the lowest: compounds 1, 3 and 2 (each within the scatter of the next, the first and the last beyond it).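

Read in this assay, the piperidin-1-yl ring on the thiocarbonyl carbon gives a step of a number 9.6 percentage points lower from compound 2 to compound 3 (within the scatter) and, against the morpholin-4-yl ring, a step of a number 2.8 percentage points higher from compound 1 to compound 3 (within the scatter) and so cannot be separated from either ring. Among the compounds shown here, the position therefore tolerates loss of the second ring hetero atom without a step beyond the scatter, and only the pair of compound 1 and compound 2, with its step of a number 12.4 percentage points higher from compound 1 to compound 2 (beyond the scatter) on record, is resolved in this set, so no ordering by ring hetero atom can be claimed across all three compounds. No available evidence accounts for any of these numbers.

Still open, from the compounds shown here alone, is how far the thiocarbonyl carbon accepts groups other than these saturated six-membered rings, such as a piperazin-1-yl ring carrying a further amine nitrogen, a seven-membered azepan-1-yl ring or an open-chain dimethylamino group. Also open is whether the small differences among these three compounds would persist in a full concentration-response comparison rather than a reading at a single concentration.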